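The source may report more compounds than this note shows. Statements on the series, on what has been measured and on what is new or still open speak of the compounds shown alone.

Series on the shared core of compound 1 `O=C(Nc1ccc(Cl)c(-c2nnc3c(Cl)cccn23)c1)c1cccc(Cl)c1`, varied only in the group on the carbonyl carbon. In a functional assay on AN3-CA cells (Homo sapiens) for antiproliferative activity, read by MTT assay, with a stated time of 72 h (a lower number here means a stronger inhibitor, a higher number a weaker inhibitor), compound 1 gives 68400 nM. Compound 2 `O=C(Nc1ccc(Cl)c(-c2nnc3c(Cl)cccn23)c1)c1c(F)cccc1Cl` reaches only the assay limit of > 100000 nM in this assay. Compound 3 `Cc1cc(Cl)ccc1C(=O)Nc1ccc(Cl)c(-c2nnc3c(Cl)cccn23)c1` also returns only a limit, > 100000 nM. Compound 3 therefore stands with a limit and no number, as does one other value (the limit of > 100000 nM in this assay, at which 2 of the 3 values shown sit). Compound 4 `O=C(Nc1ccc(Cl)c(-c2nnc3c(Cl)cccn23)c1)c1ccon1` carries 1,2-oxazol-3-yl in place of 4-chloro-2-methylphenyl on a carbonyl carbon. Among the measured compounds shown here, the steps that bear on this change are an at least 1.4-fold higher number from compound 1 to compound 2 (0.16 log units; that floor lies within the scatter) and an at least 1.4-fold higher number from compound 1 to compound 3 (0.16 log units; that floor lies within the scatter), while a step that the two limits leave unreadable from compound 2 to compound 3. None of them has a readable size, so no step beyond the scatter can be expected in this assay. Compound 4 is estimated at 100000 nM, between 40000 nM and 300000 nM, meaning an expected a number no higher from compound 3 to compound 4 (the limit leaves the size open).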

Compound 4, half-maximal inhibitory concentration: > 100000 nM
Compound 4: only a limit was reported; the forecaster's own chance of this, stated with the estimate: 60%; the middle value lies on the limit itself.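

Swapping the carbon-only six-membered ring for the five-membered 1,2-oxazol-3-yl ring, with its 2 hydrogen-bond acceptors, still gives no number in this assay, so a heteroaromatic group on the carbonyl carbon joins the substituted phenyl groups at the limit: the limit of > 100000 nM in this assay, at which 3 of the 4 values shown sit.

Against compound 1, the result is an at least 1.4-fold higher number from compound 1 to compound 4 (0.16 log units; that floor lies within the scatter). The steps from compound 2 and from compound 3 to compound 4 cannot be read.

From the compounds shown here alone, whether a piperidine or a carboxylic acid on the carbonyl carbon would return a number remains open. The limit also leaves the true order of compound 2, compound 3 and compound 4 open.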